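One Substituent Exchange on a Shared Core, Cytotoxicity Estimated

The compounds below may be only part of what the source reports. "The series", "measured", "known", "first", "only" and "open" are said of these compounds alone.

Three compounds built on one shared core were tested in a functional assay on Ehrlich cells (Mus musculus) for cytotoxicity, read by trypan blue exclusion, with a stated time of 2 h, tested at 10 ug/mL; a lower number here means a weaker effect, a higher number a stronger effect of the compound at the concentration tested. Compound 1 `Cc1ccc(C(=O)NC2=C(C#N)C(c3ccc(Cl)cc3Cl)C3=C(CCCC3=O)N2c2ccc(S(N)(=O)=O)cc2)cc1` gives 20%. Compound 2 `NC(=O)C1=C(N)N(c2ccc(S(N)(=O)=O)cc2)C2=C(C(=O)CCC2)C1c1ccc(Cl)cc1Cl` gives 30%, and compound 3 `NC1=C(C(=O)O)C(c2ccc(Cl)cc2Cl)C2=C(CCCC2=O)N1c1ccc(S(N)(=O)=O)cc1` gives 0%. Among these three numbers compound 1 stands second highest; its nearest neighbour is compound 2, a gap within the usual scatter, while compound 3 lies further off, beyond the scatter.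

Compound 4 `CCO/C=N/C1=C(C#N)C(c2ccc(Cl)cc2Cl)C2=C(CCCC2=O)N1c1ccc(S(N)(=O)=O)cc1` has not yet been measured. It differs from compound 1 in one place: a group of 5 heavy atoms (3 carbon, 1 nitrogen, 1 oxygen; no ring) in place of a group of 10 heavy atoms (8 carbon, 1 nitrogen, 1 oxygen; one six-membered aromatic ring of carbon only), on a double-bonded ring carbon The ((4-methylphenyl)carbonyl)amino group leaves and a smaller group with no ring enters, on a double-bonded ring carbon next to the ring nitrogen.

Within the data shown here, the only measured step, a number 30 percentage points lower from compound 2 to compound 3 (beyond the scatter), concerns a hydroxy in place of an amino on a carbonyl carbon, a different place on the core, so it does not bear on this change. Among the measured compounds shown here, with no step touching the same place, no change beyond the scatter is expected. Compound 4 is therefore estimated at 20%, ranging from 0% to 45%. That estimate means a step of no change at the digits printed from compound 1 to compound 4 (within the scatter).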

Compound 4, a percentage reported as activity, at one concentration (the size of the read-out at that concentration, not a potency): 30%
Compound 4: middle estimate off by 10 percentage points, on the low side; low and high end bracket the measured number.
By their numbers in this assay, from the lowest: compound 3; then compounds 1, 2 and 4 (each within the scatter of the next).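

In this assay, the ((4-methylphenyl)carbonyl)amino group gives way to a smaller group with no ring, and the result is a number 10 percentage points higher from compound 1 to compound 4 (within the scatter). Among these compounds, this is the first look at this position on the double-bonded ring carbon next to the ring nitrogen, and for this pair, losing the six-membered aromatic ring and the hydrogen-bond donor of the leaving group does not move the read-out beyond the scatter. No measured evidence is available to explain this result.

The compounds shown leave open how other groups at this place would behave, such as a dimethylamino group or a morpholine ring. With a single tested concentration, they also leave open whether compound 1 and compound 4 would stay within the scatter of each other at other concentrations.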